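This account rests on a few compounds, and the source may have more. Where it says the series, first, only, none or still open, it means among the compounds named here.

Compound 1 `Cc1nc(-c2nc3ccccc3[nH]2)c(N2CCN(C(=O)Cn3cnc4cccnc43)[C@H](C)C2)s1` gives 9 nM in a functional assay on CHO-K1 cells for antagonist activity at C-X-C chemokine receptor type 3 (Homo sapiens), read by FLIPR, with a stated time of 10 min; a higher number here means a weaker inhibitor, a lower number a stronger inhibitor. Compound 2 `C[C@@H]1CN(c2sc(C3COC3)nc2-c2nc3ccccc3[nH]2)CCN1C(=O)Cn1cnc2cccnc21` gives 53 nM. Compound 3 `COc1ncc(-c2nc(C(F)(F)F)sc2N2CCN(C(=O)Cn3cnc4cccnc43)[C@H](C)C2)cn1` gives 3.8 nM.

Among these three, compound 3 has the lowest number, with compound 1 nearest and compound 2 furthest. Compound 4 `COCCOc1ncc(-c2nc(C(F)(F)F)sc2N2CCN(C(=O)Cn3cnc4cccnc43)[C@H](C)C2)cn1` differs from compound 3 by methoxymethyl in place of hydrogen on a saturated chain carbon bound to an oxygen on an aromatic ring. For the measured compounds named here, the only step measured between compounds differing in one place is a 5.9-fold higher number from compound 1 to compound 2 (0.77 log units; beyond the scatter), which changed a group on an aromatic carbon of the shared core, a different place from the chain altered here. Going by the values given here, no measured step touches that chain, so the expectation rests on weak ground. The expected change in this assay is small, likely within the scatter. Compound 4 is expected to give about 5 nM (range 1.5 nM to 16 nM). That corresponds to an expected step of a 1.3-fold higher number from compound 3 to compound 4 (0.12 log units; within the scatter).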

Compound 4, half-maximal inhibitory concentration: 4.7 nM
Beside the measured number, compound 4's estimate is 1.1-fold (0.03 log units) above it; low and high end bracket the measured number.
By their numbers in this assay, from the lowest: compounds 3, 4 and 1 (each within the scatter of the next, the first and the last beyond it); then compound 2.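

In this assay, the change from methoxy to 2-methoxyethoxy gives a 1.2-fold higher number from compound 3 to compound 4 (0.09 log units; within the scatter) and so shows that this chain takes the added methoxymethyl with no change beyond the scatter. For the compounds shown here, the only earlier step, oxetan-3-yl in place of methyl, lay at a different place, on an aromatic carbon of the shared core, and went beyond the scatter. Nothing measured here gives a reason for this result. As far as these compounds go, whether this tolerance extends to a longer chain, or to an amine or a carboxylic acid at the end of this chain, stays open.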